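This account rests on a few compounds, and the source may have more. Where it says the series, first, only, none or still open, it means among the compounds named here.

Compound 1 `O=C(/C=C/c1cccnc1)NCCCCCCc1ccc(S(=O)(=O)Nc2ccccc2)cc1`: 36 nM
Compound 2 `O=C(/C=C/c1cccnc1)NCCCCCCCc1ccc(S(=O)(=O)Nc2ccccc2)cc1`: 37.6 nM
Compound 3 `Cc1cccc(NS(=O)(=O)c2cccc(CCCCCCNC(=O)/C=C/c3cccnc3)c2)c1`: 4 nM

In a functional assay on MCF7 cells (Homo sapiens) for inhibition, read by CCK-8 assay, with a stated time of 72 h (on this read-out higher numbers stand for weaker inhibition and lower numbers for stronger inhibition), compound 3 stands lowest of the three, and its gap to each of the others lies beyond the scatter. Compound 1 and compound 2 lie within the scatter of each other.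

Compound 4 `O=C(/C=C/c1cccnc1)NCCCCCCc1cccc(S(=O)(=O)Nc2ccc(F)c(Cl)c2)c1` carries 3-chloro-4-fluorophenyl in place of 3-methylphenyl on a sulfonamide nitrogen. Among the compounds with values here, no measured pair shows what this change does. The entering group, like the leaving one, is one six-membered aromatic ring of carbon only, so no step beyond the scatter is expected in this assay. The starting point is compound 3 at 4 nM. The expected step (a 1.3-fold higher number from compound 3 to compound 4 (0.10 log units; within the scatter)) is accordingly small. The estimate for compound 4 is 5 nM with an expected range from 1.5 nM to 20 nM in this read-out.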

Compound 4, half-maximal inhibitory concentration: 6.3 nM
Compound 4: middle estimate off by 1.3-fold (0.10 log units), on the low side, within the range that was stated.
By their numbers in this assay, from the lowest: compounds 3 and 4 (each within the scatter of the next); then compounds 1 and 2 (each within the scatter of the next).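

In this assay, 3-chloro-4-fluorophenyl in place of 3-methylphenyl on a sulfonamide nitrogen gives a 1.6-fold higher number from compound 3 to compound 4 (0.20 log units; within the scatter). This single-place comparison shows that the position accepts a ring carrying chlorine and fluorine without a change that can be read beyond the scatter. No measured evidence accounts for this result. The compounds shown leave open whether a pyridine ring, a cyclohexyl group or a phenyl ring bearing a carboxylic acid on that nitrogen would give a number like those of compound 3 and compound 4.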